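The compounds below may be only part of what the source reports. "The series", "measured", "known", "first", "only" and "open" are said of these compounds alone.

Measured compounds:
- compound 1 `c1ccc(-c2nnc(-c3nsc4ccccc34)s2)cc1`: 10%
- compound 2 `CCn1c(S)nnc1-c1nsc2ccccc12`: 50%

For the measured compounds named here, in a functional assay on the whole organism for inhibition, with Rattus norvegicus as the target, with a stated time of 3.5 h, at a dose of 100 mg/kg by the intraperitoneal route (a lower number here means less inhibition, a higher number more inhibition at the dose given (going by the name of the read-out)), compound 2 stands highest of the two numbers so far. Its nearest neighbour is compound 1, which in this assay gives 10%, a gap beyond the usual scatter; compound 1 has a different core, so its values are compared here only side by side, not as a single step. From compound 2 a new compound follows, compound 3 `Sc1nnc(-c2nsc3ccccc23)n1-c1ccccc1`, not yet tested in this assay. The change is phenyl in place of ethyl on an aromatic nitrogen.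

Going by the values given here, no measured pair shows what this kind of swap does on this core, so the direction of the step from compound 2 to compound 3 cannot be read from the existing numbers. With a phenyl in place of an ethyl on the aromatic nitrogen, the expectation is a small step, not beyond the scatter in either direction, so that the step of a number 5 percentage points lower from compound 2 to compound 3 (within the scatter) is expected to be close to nothing. Compound 3 is therefore estimated at 45% in this assay, with a range from 20% to 70%, wide because only compound 2 with 50% anchors it.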

Compound 3, a percentage reported as inhibition, in the whole organism at one dose (the size of the read-out at that dose, not a potency): 60%
For compound 3 the middle estimate is 15 percentage points below the measured one, and the stated range covers the measured number.
By their numbers in this assay, from the lowest: compound 1; then compounds 2 and 3 (each within the scatter of the next).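

In this assay the swap of phenyl in place of ethyl on the aromatic nitrogen gives a number 10 percentage points higher from compound 2 to compound 3 (within the scatter) and so leaves the read-out unchanged within the usual scatter. For the compounds shown here, this is the first view of this position: on the shared core, the nitrogen can carry either a small open chain or a much larger six-membered aromatic ring of carbon only, and the read-out at this single dose still does not separate the two compounds. Nothing measured here explains why these two different groups give such similar results.

The compounds shown give only two points at this position, both made of carbon alone, so it remains open whether a longer chain such as butyl, a chain ending in an amine, or a carboxylic acid on the same nitrogen would keep the read-out at this level. Also open, on these data alone, is how much the neighbouring sulfanyl group contributes, as every compound with this nitrogen substituent still carries it, and a single dose cannot show whether compound 2 and compound 3 would differ at other doses.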